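Moving the amino group on the nitrogen-bound phenyl

The compounds below may be only part of what the source reports. "The series", "measured", "known", "first", "only" and "open" are said of these compounds alone.

Measured in a functional assay on MCF7 cells (Homo sapiens) for cytotoxicity, read by MTT assay, with a stated time of 96 h; on this read-out higher numbers stand for weaker inhibition and lower numbers for stronger inhibition:
- compound 1 `COc1cc(C(=O)c2cn(-c3cccc(N)c3)cc2-c2ccccc2Cl)cc(OC)c1OC`: 40 nM
- compound 2 `COc1cc(C(=O)c2cn(-c3cccc(N)c3)cc2-c2cccc(N)c2)cc(OC)c1OC`: 60 nM
- compound 3 `COc1cc(C(=O)c2cn(-c3cccc(N)c3)cc2-c2ccc(N)cc2)cc(OC)c1OC`: 14 nM

The starting point is compound 2 at 60 nM. Its nearest neighbour cannot be separated from it: a 1.5-fold higher number from compound 1 to compound 2 (0.18 log units; within the scatter). Its furthest neighbour stands clear: a 4.3-fold lower number from compound 2 to compound 3 (0.63 log units; beyond the scatter).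

The next analogue is compound 4 `COc1cc(C(=O)c2cn(-c3ccc(N)cc3)cc2-c2cccc(N)c2)cc(OC)c1OC`. The change is 4-aminophenyl in place of 3-aminophenyl on an aromatic nitrogen, so 4-aminophenyl replaces 3-aminophenyl on an aromatic nitrogen, while the 3-aminophenyl on the carbon stays.

Within the data shown here, no measured step changes the group on that nitrogen, so the evidence is indirect. Among the measured compounds shown here, the nearest precedent is the same exchange made on an aromatic carbon: a 4.3-fold lower number from compound 2 to compound 3 (0.63 log units; beyond the scatter). A second step to the 4-aminophenyl group on carbon points the same way: a 2.9-fold lower number from compound 1 to compound 3 (0.46 log units; beyond the scatter). Going by these compounds, whether either carries over to the nitrogen is unknown, so only part of that size is assumed, and the direction remains a lean rather than a firm call in this assay. The expected step is a 1.7-fold lower number from compound 2 to compound 4 (0.23 log units; within the scatter). The estimate for compound 4 is 35 nM, with an expected range of 10 nM to 120 nM.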

Compound 4, half-maximal inhibitory concentration: 78 nM
Estimate against measurement, compound 4: 2.2-fold (0.35 log units) below; measured number inside the range.
By their numbers in this assay, from the lowest: compound 3; then compounds 1, 2 and 4 (each within the scatter of the next).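

In this assay the exchange of 3-aminophenyl for 4-aminophenyl on the aromatic nitrogen, with the 3-aminophenyl on the carbon kept, does not separate the pair (a 1.3-fold higher number from compound 2 to compound 4 (0.11 log units; within the scatter)). The same exchange on the aromatic carbon, with the 3-aminophenyl on the nitrogen kept, stands clear (a 4.3-fold lower number from compound 2 to compound 3 (0.63 log units; beyond the scatter)), so the two positions do not respond alike in these pairs, and a result at the carbon cannot be read across to the nitrogen. No measurement at hand speaks to what sets the two positions apart.

Still open is whether the nitrogen position stays this flat when the carbon carries 4-aminophenyl or 2-chlorophenyl instead of 3-aminophenyl, since the exchange is shown only against a single partner. Also open, going by these compounds, is whether the amine on the nitrogen-bound phenyl matters at all, which a plain phenyl or a 4-hydroxyphenyl on that nitrogen would test against the 3-aminophenyl and 4-aminophenyl groups.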